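A Thiophene Carbonyl in Place of a Bromophenyl Sulfonyl

The source may report more compounds than this note shows. Statements on the series, on what has been measured and on what is new or still open speak of the compounds shown alone.

Measured so far:
compound 1 `CC(C)=CCC1Cc2c(O)cc(=O)n(CCCO)c2CC1(C)C`: 0%
compound 2 `CC(C)=CCOc1cc(=O)n(CCCO)c2c1CC(CC=C(C)C)C(C)(C)C2`: 7.5%
compound 3 `CC(C)=CCC1Cc2c(OCCCNS(=O)(=O)c3ccc(Br)cc3)cc(=O)n(CCCO)c2CC1(C)C`: 3.7%

All three compounds were tested in a functional assay on PANC-1 cells (Homo sapiens) for inhibition, read by MTT assay, with a stated time of 24 h, tested at 10 uM; a lower number here means less inhibition, a higher number more inhibition at the concentration tested (going by the name of the read-out). Within the data shown here, the only single-point change among them, a number 7.5 percentage points higher from compound 1 to compound 2 (within the scatter), stays within the scatter, so nothing measured so far moves the read-out convincingly. Compound 3 carries a longer chain on the ring oxygen of the shared core, capped by a (4-bromophenyl)sulfonyl on an amine nitrogen. Its number is the middle one of the three, yet the gaps to compound 1 and to compound 2 are both within the scatter, and the three compounds cannot be told apart on this read-out.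

Compound 4 `CC(C)=CCC1Cc2c(OCCCNC(=O)c3cccs3)cc(=O)n(CCCO)c2CC1(C)C` keeps everything of compound 3 except the cap on that amine nitrogen: (thiophen-2-yl)carbonyl in place of (4-bromophenyl)sulfonyl on an amine nitrogen. Among the measured compounds shown here, no measured step bears on this position; the one step seen concerns the ring oxygen, not the amine nitrogen. For the measured compounds named here, with three essentially flat numbers as the only guide, compound 4 is expected to stay flat too, a step of a number 0.3 percentage points higher from compound 3 to compound 4 (within the scatter), with no direction beyond the scatter. The estimate for compound 4 is 4%, with a range from 0% to 15%.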

Compound 4, a percentage reported as inhibition, at one concentration (the size of the read-out at that concentration, not a potency): 5.6%
For compound 4 the middle estimate is 1.6 percentage points below the measured one, and the stated range covers the measured number.
By their numbers in this assay, from the lowest: compounds 1, 3, 4 and 2 (each within the scatter of the next).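

In this assay, the amine nitrogen now has a measured step of its own: (thiophen-2-yl)carbonyl in place of (4-bromophenyl)sulfonyl gives a number 1.9 percentage points higher from compound 3 to compound 4 (within the scatter), so these two caps cannot be told apart, even though they differ in ring type and in size, at 7 and 10 heavy atoms. The wider comparisons agree, with 3-(((thiophen-2-yl)carbonyl)amino)propyl in place of hydrogen on the ring oxygen giving a number 5.6 percentage points higher from compound 1 to compound 4 (within the scatter), and 2-(((thiophen-2-yl)carbonyl)amino)ethyl in place of 2-methylprop-1-en-1-yl on the saturated chain carbon bound to that oxygen giving a number 1.9 percentage points lower from compound 2 to compound 4 (within the scatter). No outside information is available to account for this flat picture.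

From the compounds shown here alone, what remains open is whether any cap on this nitrogen can shift the read-out beyond the scatter, for example a free amine with no cap at all, or a carbonyl bearing a carboxylic acid or a simple pyridine ring. Also open, going by these compounds, is whether a longer chain between the ring oxygen and the amine nitrogen would separate compounds that the present set leaves indistinguishable.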